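A few compounds are considered here, and "the series" means these few. Any claim that something is new, unique, unknown or untested is made for them only; others in the source may bear on it.

Measured compounds:
compound 1 `Cc1cccc(C#Cc2ccc3c(n2)CCN(C)C3=O)c1` – 820 nM
compound 2 `Cc1ccc(C#Cc2ccc3c(n2)CCN(C)C3=O)cc1` – 7450 nM
compound 3 `CC(C)N1CCc2nc(C#Cc3ccccc3)ccc2C1=O` – 1280 nM

These three share a core and differ in the group on the triple-bonded carbon and on the amide nitrogen. In an assay on HEK293 cells for displacement of a labelled ligand from metabotropic glutamate receptor 5 (Homo sapiens), with a stated time of 2 h (on this read-out higher numbers stand for weaker inhibition and lower numbers for stronger inhibition), compound 3 stands second highest of the three numbers: compound 1 sits a little lower, a gap within the usual scatter, while compound 2 sits well higher, a gap beyond it.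

Compound 4 `CC(C)N1CCc2nc(C#Cc3ccccc3Cl)ccc2C1=O` takes compound 3 and makes one change: chloro in place of hydrogen on an aromatic carbon. Cut one bond further out, this reads phenyl to 2-chlorophenyl, the chloro sitting on an aromatic carbon of the carbon-only six-membered ring, ortho to a large group.

Going by the values given here, no measured step adds a chloro, and none places a group at this position. Among the compounds with values here, the one step that bears on it is a 9.1-fold higher number from compound 1 to compound 2 (0.96 log units; beyond the scatter), which shows that moving a small group around this phenyl ring can shift the number well beyond the scatter. How a group at this new position behaves is simply unknown from these data, so the expectation carries wide uncertainty: a modest rise in this assay is expected, a 1.7-fold higher number from compound 3 to compound 4 (0.24 log units; within the scatter).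

Compound 4 is therefore estimated at 2200 nM, with a range from 700 nM to 7000 nM.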

Compound 4, inhibition constant: 5680 nM
The estimate for compound 4 lay 2.6-fold (0.41 log units) below the measured number; low and high end bracket the measured number.
By their numbers in this assay, from the lowest: compounds 1 and 3 (each within the scatter of the next); then compounds 4 and 2 (each within the scatter of the next).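

In this assay, chloro in place of hydrogen on an aromatic carbon, ortho to a large group, gives a 4.4-fold higher number from compound 3 to compound 4 (0.65 log units; beyond the scatter), so this one added heavy atom moves the number beyond the scatter towards weaker inhibition. Going by these compounds alone, the earlier compounds showed only that shifting a methyl group around the phenyl ring can change the number; this step shows that a substituent at this new place on the unsubstituted phenyl ring of compound 3 also matters, and that chloro here is not tolerated without loss. Nothing measured here gives a reason for this rise.

From the compounds shown here alone, whether the rise belongs to chloro itself or would follow any group at this place stays open: a fluoro, a methoxy or a nitrile on the same carbon would help to tell these apart. Also open, going by these compounds, is whether chloro would move the number the same way at another carbon of the phenyl ring, or with a methyl group in place of the isopropyl group on the amide nitrogen.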